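The source may report more compounds than this note shows. Statements on the series, on what has been measured and on what is new or still open speak of the compounds shown alone.

Measured in an ADME assay on MT4 cells (Homo sapiens) for cytotoxicity, read by MTT assay; a lower number here means that less compound is tolerated, a higher number that more compound is tolerated
compound 1 `O=C(CSc1nncnc1-c1ccccc1Cl)Nc1ccccc1` gives 127000 nM
compound 2 `COC(=O)c1ccc(NC(=O)CSc2nncnc2-c2ccccc2Cl)c(Br)c1` gives 59000 nM

Compound 1 holds the higher of the two numbers, and compound 2 lies lower by more than the scatter. Compound 3 `O=C(CSc1nncnc1-c1ccccc1Cl)Nc1cccnc1Cl` is not yet measured and has 2-chloropyridin-3-yl in place of phenyl on an amide-type nitrogen. Among the compounds with values here, no measured pair isolates this change, so the only guide is that compound 2 at 59000 nM lies under compound 1 at 127000 nM and the data show nothing higher. The expected step is a 1.6-fold lower number from compound 1 to compound 3 (0.20 log units; within the scatter) and points downward, within the scatter or close to it. In this assay the estimated value for compound 3 is 80000 nM with an expected range of 30000 nM to 160000 nM around it.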

Compound 3, half-maximal cytotoxic concentration: 167000 nM
Estimate against measurement, compound 3: 2.1-fold (0.32 log units) below; the whole stated range lies below it.
By their numbers in this assay, from the lowest: compound 2; then compounds 1 and 3 (each within the scatter of the next).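

Within the data shown here, the change to 2-chloropyridin-3-yl on the amide-type nitrogen gives a 1.3-fold higher number from compound 1 to compound 3 (0.12 log units; within the scatter) in this assay and is the first single-place comparison. At this position, the swap of phenyl for a ring with a hetero atom and a chlorine therefore leaves the number within the scatter. Nothing at hand explains this result.

As far as these compounds go, the separate contributions of the ring nitrogen and the chlorine remain open, as a chlorophenyl or unsubstituted pyridinyl group would be needed to separate them. From the compounds shown here alone, how a carboxylic acid or an amine on this ring would read also remains open.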